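A few compounds are considered here, and "the series" means these few. Any claim that something is new, unique, unknown or untested is made for them only; others in the source may bear on it.

In a functional assay on KB cells (Homo sapiens) for inhibition, read by MTT assay, with a stated time of 24 h, tested at 10 ug/mL (a higher number here means more inhibition of growth at the concentration tested, a lower number less inhibition of growth), compound 1 (`O=C(CCCCC1CCSS1)Nc1ccccn1`) gives "not active" (no number reported) with no number attached. Within the data shown here, compound 2 (`O=C(CCCCC(S)CCS)Nc1ccccc1`) gives 8.62% as the only number so far. Compound 3 (`O=C(CCCCC(S)CCS)Nc1ccccn1`) is still unmeasured and differs from compound 2 by pyridin-2-yl in place of phenyl on an amide-type nitrogen as pyridin-2-yl in place of phenyl on an amide-type nitrogen. Among the measured compounds shown here, no measured pair carries this swap, so in this assay no shift beyond the scatter is expected in either direction. The expected step of a number 1.4 percentage points higher from compound 2 to compound 3 (within the scatter) stays small. Compound 3 is estimated at 10% with an expected range from 0% to 22% for repeat readings.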

Compound 3, percent growth inhibition at one concentration: 0.28%
Estimate against measurement, compound 3: 9.7 percentage points above; low and high end bracket the measured number.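

In this assay, among these compounds, pyridin-2-yl in place of phenyl on an amide-type nitrogen gives a number 8.3 percentage points lower from compound 2 to compound 3 (within the scatter) and is the first readable step. At this position, the swap that adds one ring nitrogen and one hydrogen-bond acceptor leaves no shift distinguishable from the scatter. No measurement here bears on what lies behind this result.

The step from compound 1 to compound 3 cannot be read, since compound 1 carries no number. Going by these compounds, whether an amine or a carboxylic acid on the amide-type nitrogen, in place of these rings, would read differently stays open.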